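Aryl Amide Return on a Thiourea Core

The source may report more compounds than this note shows. Statements on the series, on what has been measured and on what is new or still open speak of the compounds shown alone.

Measured so far:
compound 1 `O=C(NC(=S)N1CCc2c(OCCCCCOc3ccc(Cl)cc3)cccc21)c1ccc(F)cc1` — 31100 nM
compound 2 `O=C(NC(=S)N1CCc2c(OCCCCCOc3ccc(Cl)cc3)cccc21)c1ccc(Cl)cc1` — 21700 nM
compound 3 `CCCC(=O)NC(=S)N1CCc2c(OCCCCCOc3ccc(Cl)cc3)cccc21` — > 50000 nM

In an ADME assay on Huh-7 cells (Homo sapiens) for cytotoxicity (on this read-out higher numbers stand for lower toxicity in this test and lower numbers for higher toxicity in this test), compound 3 stands at a limit of the test rather than a number, sitting at the limit of > 50000 nM in this assay, at which 1 of the 3 values shown sits. Compound 4 `O=C(NC(=S)N1CCc2c(OCCCCCOc3ccc(Cl)cc3)cccc21)c1cccnc1` is the unmeasured analogue; the change is pyridin-3-yl in place of propyl on a carbonyl carbon. Within the data shown here, two measured steps bear on this change: the step of an at least 1.6-fold higher number from compound 1 to compound 3 (0.20 log units; that floor lies within the scatter) and the step of an at least 2.3-fold higher number from compound 2 to compound 3 (0.36 log units; beyond the scatter), both of which replace an aryl group on the carbonyl carbon with propyl and move the number upward to the limit. Compound 4 reverses that direction, putting an aryl group back on the carbonyl carbon, so a step back toward the values of compound 1 and compound 2 is expected in this assay. The estimated step is an at least 1.4-fold lower number from compound 3 to compound 4 (0.15 log units; that floor lies within the scatter). Compound 4 is therefore expected to give about 35000 nM in this assay, within a range from 15000 nM to 80000 nM.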

Compound 4, half-maximal cytotoxic concentration: 11100 nM
Estimate against measurement, compound 4: 3.2-fold (0.50 log units) above; measured number below the stated range.
By their numbers in this assay, from the lowest: compounds 4, 2 and 1 (each within the scatter of the next, the first and the last beyond it). At a limit, above all of these: compound 3.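

In this assay, pyridin-3-yl in place of propyl on the carbonyl carbon gives an at least 4.5-fold lower number from compound 3 to compound 4 (0.65 log units; beyond the scatter), so among the compounds shown the propyl amide alone reaches the limit, while all three ring-bearing amides give numbers. The ring nitrogen does not place compound 4 between the halophenyl amides and that limit: the comparison with the 4-fluorophenyl amide gives a 2.8-fold lower number from compound 1 to compound 4 (0.45 log units; beyond the scatter), and the one with the 4-chlorophenyl amide gives a 2.0-fold lower number from compound 2 to compound 4 (0.29 log units; within the scatter). Compound 3 has a limit of the test and not a number, so its step gives only a floor: the limit of > 50000 nM in this assay, at which 1 of the 4 values shown sits.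

The compounds shown leave open whether pyridin-2-yl or pyridin-4-yl would read like pyridin-3-yl, and how plain phenyl would compare. They also leave open whether cyclohexyl or a chain longer than propyl would stay at the limit.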